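The source may hold more compounds than are shown below. What is called first, only, known or untested is meant among the compounds shown, and "the series" means these compounds.

Measured compounds:
compound 1, `C[C@H](NS(=O)(=O)c1cc(C(F)(F)F)nn1C)c1nc(-c2cccc(F)c2)no1`, > 30000 nM
compound 2, `Cc1cccc(-c2noc([C@H](C)NC(=O)c3cc(C(F)(F)F)nn3C)n2)n1`, > 30000 nM

In an assay on T-REx-293 cells for inhibition of potassium channel subfamily T member 1 (Homo sapiens), read by patch clamp (a lower number here means a stronger inhibitor, a higher number a weaker inhibitor), compound 1 gives > 30000 nM, which is a limit of the assay rather than a number. Compound 2 gives > 30000 nM in this assay, again a limit. Among the measured compounds shown here, both values shown sit at the limit of > 30000 nM in this assay, at which 2 of the 2 values shown sit, so compound 2 stands at the same limit as the only other compound, and no numerical potency is known for either. Compound 3, `CO[C@H](C)c1cc(-c2noc([C@H](C)NC(=O)c3cc(C(F)(F)F)nn3C)n2)ccn1`, is not yet measured. It differs from compound 2 by a group of 10 heavy atoms (8 carbon, 1 nitrogen, 1 oxygen; one six-membered aromatic ring with 1 hetero atom) in place of a group of 7 heavy atoms (6 carbon, 1 nitrogen; one six-membered aromatic ring with 1 hetero atom), on an aromatic carbon; the entering group carries a defined stereocentre. For the measured compounds named here, no step between measured compounds is available to anchor this change, and two limits alone give no trend. The step of an at least 1.2-fold lower number from compound 2 to compound 3 (0.07 log units; that floor lies within the scatter) is expected to stay within the scatter, if any number is obtained at all. Compound 3 is estimated at 25000 nM, between 5000 nM and 100000 nM, with a real chance that only a limit is reported again.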

Compound 3, half-maximal inhibitory concentration: 778 nM
Beside the measured number, compound 3's estimate is 32-fold (1.51 log units) above it; measured number outside the range, below it.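

In this assay, the aromatic carbon between two ring nitrogen atoms proves sensitive to what it carries: replacing 6-methylpyridin-2-yl with the entering group, which keeps a six-membered aromatic ring with 1 hetero atom and adds a defined stereocentre, gives an at least 38-fold lower number from compound 2 to compound 3 (1.58 log units; beyond the scatter). The step is a floor and not a full size, because one end of it is a limit: the limit of > 30000 nM in this assay, at which 2 of the 3 values shown sit. Among the compounds shown here, compound 3 is the first compound here with a number, so a change at this position alone is enough to leave that limit.

As far as these compounds go, it remains open which part of the entering group carries the step: the methoxy group, its branched carbon or the stereocentre. Also open, from the compounds shown here alone, is whether a hydroxyl or an amine in place of the methoxy group would keep a measurable number.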